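This account rests on a few compounds, and the source may have more. Where it says the series, first, only, none or still open, it means among the compounds named here.

Measured compounds: compound 1 `COC(=O)Nc1cccc2c1CCCC2c1c[nH]cn1` with 148 nM in an assay on isolated protein for binding affinity to Alpha-1A adrenergic receptor (Bos taurus), read by radioligand binding; on this read-out higher numbers stand for weaker inhibition and lower numbers for stronger inhibition; compound 2 `Oc1cccc2c1CCCC2c1c[nH]cn1` with 115 nM in this assay.

Among the compounds with values here, compound 2 holds the lowest of the two numbers, its only neighbour being compound 1, and a 1.3-fold lower number from compound 1 to compound 2 (0.11 log units; within the scatter). Compound 3 `Nc1cccc2c1CCCC2c1c[nH]cn1` carries amino in place of hydroxy on an aromatic carbon. Within the data shown here, the single measured step, from (methoxycarbonyl)amino to hydroxy, stayed within the scatter, so for compound 3 no step beyond the scatter is expected in this assay; the step of a 1.1-fold higher number from compound 2 to compound 3 (0.05 log units; within the scatter) is an estimate only. Compound 3 is expected at 130 nM, between 50 nM and 350 nM.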

Compound 3, inhibition constant: 138 nM
Beside the measured number, compound 3's estimate is 1.1-fold (0.03 log units) below it; measured number inside the range.
By their numbers in this assay, from the lowest: compounds 2, 3 and 1 (each within the scatter of the next).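

In this assay, amino in place of hydroxy on an aromatic carbon gives a 1.2-fold higher number from compound 2 to compound 3 (0.08 log units; within the scatter), and hydrogen in place of methoxycarbonyl on the nitrogen gives a 1.1-fold lower number from compound 1 to compound 3 (0.03 log units; within the scatter). With compound 3, this position now carries three different groups, hydroxy, amino and (methoxycarbonyl)amino, and all three compounds lie within the scatter of one another, so this assay does not separate them.

Still open, going by these compounds, is whether a carboxylic acid, a methoxy group or plain hydrogen at this position would give a step beyond the scatter. No evidence is available on why these three groups read alike.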